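Methyl for cyano on the aryl piperazine of compound 1

The compounds below may be only part of what the source reports. "The series", "measured", "known", "first", "only" and "open" are said of these compounds alone.

The study measures inhibition in a functional assay on HT-29 cells (Homo sapiens) for inhibition, read by sulforhodamine B assay; a higher number here means a weaker inhibitor, a lower number a stronger inhibitor. Compound 1, `COC(=O)CC/C(C)=C/Cc1c(OC)c(C)c2c(c1OCC#CCN1CCN(c3ccc(C#N)cc3)CC1)C(=O)OC2`, gives in this assay only a limit of > 50000 nM, so its true position is not fixed by a number. This is the case described by the limit of > 50000 nM in this assay, at which 1 of the 2 values shown sits. Compound 2, `CCCCNc1ccc(CC#CCOc2c(C/C=C(\C)CCC(=O)OC)c(OC)c(C)c3c2C(=O)OC3)cc1`, is a distinct structure with a butylaminophenyl chain in place of the piperazine, and in this assay compound 2 gives 36700 nM; both measured compounds sit at the weak end of the scale.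

Compound 3, `COC(=O)CC/C(C)=C/Cc1c(OC)c(C)c2c(c1OCC#CCN1CCN(c3ccc(C)cc3)CC1)C(=O)OC2`, has not yet been measured. It differs from compound 1 by methyl in place of cyano on an aromatic carbon, the change sitting on an aromatic carbon of the six-membered carbon ring of the piperazine substituent.

Among the compounds with values here, with compound 1 known only as a limit, no measured step exists to set a scale. The step of a number no higher from compound 1 to compound 3 (the limit leaves the size open) is expected to lie within the scatter, in either direction. Compound 3 is therefore expected at about 50000 nM in this assay, within a range from 15000 nM to 160000 nM, with a real chance that only a limit is reported again.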

Compound 3, half-maximal inhibitory concentration: > 50000 nM
Compound 3: no number, only a limit; the forecaster's own chance of this, stated with the estimate: 55%; the middle value sits exactly at the limit.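

In this assay compound 3 gives only a limit, > 50000 nM. Within the data shown here, compound 1 is also known only as a limit, so no step between compound 1 and compound 3 can be read. The compounds shown leave open whether methyl in place of cyano changes inhibition at all, and the values crowd at one point: the limit of > 50000 nM in this assay, at which 2 of the 3 values shown sit.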